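Trifluoromethyl for chloro on the anilide ring

The source may hold more compounds than are shown below. What is called first, only, known or untested is meant among the compounds shown, and "the series" means these compounds.

Compound 1 `COc1cc(-c2cc(C(=O)O)c3ccccc3n2)ccc1OCC(=O)Nc1ccccc1C` gives 0.8 in a physicochemical assay for lipophilicity, using the shake flask method, in phosphate buffer, measured as octanol-water partition, at pH 7.4; a lower number here means a more polar compound, a higher number a more lipophilic compound.
Compound 2 `COc1cc(-c2cc(C(=O)O)c3ccccc3n2)ccc1OCC(=O)Nc1cccc(F)c1` gives 1.6 in this assay.
Compound 3 `COc1cc(-c2cc(C(=O)O)c3ccccc3n2)ccc1OCC(=O)Nc1cccc(Cl)c1` gives 2.3 in this assay.

Compound 3 stands highest of the three: the step of a number 0.70 log units higher from compound 2 to compound 3 (beyond the scatter) and the step of a number 1.50 log units higher from compound 1 to compound 3 (beyond the scatter) both lie beyond the scatter. Compound 4 `COc1cc(-c2cc(C(=O)O)c3ccccc3n2)ccc1OCC(=O)Nc1cccc(C(F)(F)F)c1` differs from compound 3 by trifluoromethyl in place of chloro on an aromatic carbon. The step that bears most directly on this change is a number 0.70 log units higher from compound 2 to compound 3 (beyond the scatter), an exchange at the same position of the same ring, which was modest. Among the measured compounds shown here, no measured step has a trifluoromethyl group, so the size must be judged from that halogen exchange alone. The step of a number 0.30 log units higher from compound 3 to compound 4 (within the scatter) is expected to be small and upward, near the edge of the scatter. Compound 4 is therefore estimated at 2.6, within a range from 2.2 to 3.1.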

Compound 4, distribution coefficient: 1.3
For compound 4 the middle estimate is 1.30 log units above the measured one; measured number outside the range, below it.
By their numbers in this assay, from the lowest: compound 1; then compounds 4 and 2 (each within the scatter of the next); then compound 3.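

In this assay, trifluoromethyl at this position does not continue the rise seen from fluoro to chloro: in place of chloro it gives a number 1.00 log units lower from compound 3 to compound 4 (beyond the scatter), and in place of fluoro it gives a number 0.30 log units lower from compound 2 to compound 4 (within the scatter), so these two groups cannot be told apart here. In place of 2-methylphenyl, 3-(trifluoromethyl)phenyl gives a number 0.50 log units higher from compound 1 to compound 4 (beyond the scatter). Nothing available accounts for the fall from chloro to trifluoromethyl. On these data alone, whether a methoxy group or a nitrile on this carbon would stand with chloro or with fluoro and trifluoromethyl stays open.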